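A Pyridin-2-yl Variant of Compound 3

The source may hold more compounds than are shown below. What is called first, only, known or untested is meant among the compounds shown, and "the series" means these compounds.

Among the measured compounds shown here, compound 3 `O=C(O)/C=C/c1ccc(/C(=C(\c2ccc(F)cc2Cl)C2CCC2)c2ccc3[nH]nc(F)c3c2)cc1` gives 2 nM in a functional assay on MCF7 cells (Homo sapiens) for cytotoxicity, read by CellTiter-Glo, with a stated time of 5 days (a lower number here means a stronger inhibitor, a higher number a weaker inhibitor), the only number in the set. Compound 1 `O=C(O)/C=C/c1ccc(/C(=C(/CCO)c2ccccc2)c2ccc3[nH]ncc3c2)cc1` is reported only as a limit of this assay, > 1000 nM. Compound 2 `CC/C(=C(/c1ccc(/C=C/C(=O)O)cc1)c1ccc2[nH]nc(C)c2c1)c1ccccc1` likewise reaches only a limit, > 1000 nM. Two of the three results thus sit at that limit (the limit of > 1000 nM in this assay, at which 2 of the 3 values shown sit), so compound 3 stands alone as the measured one. Compound 4 `O=C(O)/C=C/c1ccc(/C(=C(\c2ccccn2)C2CCC2)c2ccc3[nH]nc(F)c3c2)cc1` differs from compound 3 by pyridin-2-yl in place of 2-chloro-4-fluorophenyl on a double-bonded chain carbon bound to a double-bonded chain carbon and a saturated ring carbon. For the measured compounds named here, no measured pair isolates this change, so the expectation rests on compound 3 alone; a modest loss beyond the scatter is expected, a 5.0-fold higher number from compound 3 to compound 4 (0.70 log units; beyond the scatter). Compound 4 is estimated at 10 nM, between 2 nM and 60 nM in this assay.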

Compound 4, half-maximal inhibitory concentration: 22 nM
Compound 4: middle estimate off by 2.2-fold (0.34 log units), on the low side; the range from low to high includes it.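

In this assay, among the compounds shown here, pyridin-2-yl in place of 2-chloro-4-fluorophenyl on this double-bonded chain carbon gives an 11-fold higher number from compound 3 to compound 4 (1.04 log units; beyond the scatter), the first step in the set that can be read. The group at this position therefore matters to the read-out, though the pyridin-2-yl still returns a measured number rather than a limit. No measurement shown accounts for the size of this loss. Going by these compounds, the change removes the chlorine and the fluorine and adds a ring nitrogen all at once, so their separate shares stay open. Also open, on these data alone, is how 2-chlorophenyl, 4-fluorophenyl or pyridin-3-yl would read on this carbon.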